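A few compounds are considered here, and "the series" means these few. Any claim that something is new, unique, unknown or untested is made for them only; others in the source may bear on it.

The study gathers three measured compounds that share a common core. Compound 1 `O=C(NCCSc1nonc1/C(=N/O)Nc1ccc(F)c(C(F)F)c1)C1CS(=O)(=O)C1` gives 13 nM in an assay for inhibition of Indoleamine 2,3-dioxygenase 1 (Homo sapiens), read by fluorescence, with a stated time of 24 h; a lower number here means a stronger inhibitor, a higher number a weaker inhibitor. Compound 2 `NS(=O)(=O)CC(=O)NCCSc1nonc1/C(=N/O)Nc1ccc(F)c(Br)c1` gives 12 nM in this assay, and compound 3 `NS(=O)(=O)NCCOc1nonc1/C(=N/O)Nc1ccc(F)c(Br)c1` gives 12 nM in this assay. Compound 1 carries the highest of the three numbers, yet its gap to compound 2 and its gap to compound 3 both lie within the scatter of repeated measurements, so the three compounds stand level on what has been measured.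

Compound 4 `CC(C)(O)CC(=O)NCCSc1nonc1/C(=N/O)Nc1ccc(F)c(C(F)F)c1` has not yet been measured. It differs from compound 1 in one place: a group of 5 heavy atoms (4 carbon, 1 oxygen; no ring) in place of a group of 6 heavy atoms (3 carbon, 2 oxygen, 1 sulfur; one four-membered non-aromatic ring with 1 hetero atom), on a carbonyl carbon. Within the data shown here, no measured pair in the set differs in just one place, so no step exists to guide the expectation directly; the only guide is that the three measured compounds, with different groups beyond the shared core, all give nearly the same number in this assay. The step from compound 1 to compound 4 is therefore expected to be a 1.2-fold higher number from compound 1 to compound 4 (0.06 log units; within the scatter), not beyond the scatter in either direction. For compound 4 the estimate in this assay is 15 nM, with a range from 6 nM to 40 nM.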

Compound 4, half-maximal inhibitory concentration: 8.4 nM
For compound 4 the middle estimate is 1.8-fold (0.25 log units) above the measured one; low and high end bracket the measured number.
By their numbers in this assay, from the lowest: compounds 4, 2, 3 and 1 (each within the scatter of the next).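

In this assay, among these compounds, placing 2-hydroxy-2-methylpropyl on the carbonyl carbon whose other neighbour is the amide-type nitrogen, in place of the four-membered sulfur-bearing ring group, gives a 1.5-fold lower number from compound 1 to compound 4 (0.19 log units; within the scatter), and this is the first direct reading at this place. It shows that, in this one pair, an open group with no ring and a hydrogen-bond donor can replace the ring group, which has no such donor, without a change beyond the scatter. No measurement given here accounts for the step.

Going by these compounds, whether an amine, a carboxylic acid or a longer chain on the same carbonyl carbon would stay in this range remains open. On these data alone, it is also open whether the same exchange would read alike with bromine in place of the difluoromethyl group.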